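Swapping the fluorophenyl group on the amide nitrogen

A few compounds are considered here, and "the series" means these few. Any claim that something is new, unique, unknown or untested is made for them only; others in the source may bear on it.

Compound 1 `CCOC(=O)C1=Cc2ccccc2OC1(OCc1cn(-c2ccc(C)cc2)nn1)C(F)(F)F`: 25100 nM
Compound 2 `CCOC(=O)C1=Cc2ccccc2OC1(OCc1cn(CC(=O)Nc2cccc(F)c2)nn1)C(F)(F)F`: > 150000 nM

In a functional assay on HeLa cells (Homo sapiens) for inhibition, read by MTT assay, with a stated time of 24 h (on this read-out lower numbers stand for stronger inhibition and higher numbers for weaker inhibition), compound 1 gives 25100 nM. For compound 2 the assay reports only a limit, > 150000 nM, not a number. Among the compounds with values here, the one measured step, an at least 5.9-fold higher number from compound 1 to compound 2 (0.77 log units; beyond the scatter), ends at the limit of > 150000 nM in this assay, at which 1 of the 2 values shown sits. Compound 3 `CCOC(=O)C1=Cc2ccccc2OC1(OCc1cn(CC(=O)Nc2ccccc2F)nn1)C(F)(F)F` differs from compound 2 only by 2-fluorophenyl in place of 3-fluorophenyl on an amide-type nitrogen. Within the data shown here, no measured step involves such a swap, so the change from compound 2 to compound 3 is expected to stay within the scatter: a number no higher from compound 2 to compound 3 (the limit leaves the size open). Compound 3 is therefore expected to give about 150000 nM, between 50000 nM and 500000 nM, quite possibly again only as a limit.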

Compound 3, half-maximal inhibitory concentration: 49900 nM
Beside the measured number, compound 3's estimate is 3.0-fold (0.48 log units) above it; measured number below the stated range.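

Where the fluorine sits matters at this amide-type nitrogen, though the atoms stay the same: 2-fluorophenyl in place of 3-fluorophenyl gives an at least 3.0-fold lower number from compound 2 to compound 3 (0.47 log units; beyond the scatter). Going by these compounds, the true size of that step stays open, as compound 2 gives only a limit, not a number: the limit of > 150000 nM in this assay, at which 1 of the 3 values shown sits. ((2-Fluorophenyl)carbamoyl)methyl in place of 4-methylphenyl gives a 2.0-fold higher number from compound 1 to compound 3 (0.30 log units; within the scatter), so the weak read-out of compound 2 does not hold for every fluorinated anilide of this kind.

Whether 4-fluorophenyl or 2-chlorophenyl on the same nitrogen would behave like compound 3 stays open, as does any reason for the difference.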